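The compounds below may be only part of what the source reports. "The series", "measured", "known", "first", "only" and "open" are said of these compounds alone.

Measured so far in an ADME assay on WI-38 cells (Homo sapiens) for cytotoxicity, read by MTT assay, with a stated time of 72 h; a higher number here means a weaker inhibitor, a lower number a stronger inhibitor:
Compound 1 `CN(C)CCn1cnnc1-c1cc(Oc2ccc(NC(=O)N/N=C/c3c[nH]c4ccccc34)cc2F)ccn1` gives 3620 nM.
Compound 2 `CN(C)CCn1cnnc1-c1cc(Oc2ccc(NC(=O)N/N=C/c3ccccc3O[N+](=O)[O-])cc2F)ccn1` gives 6860 nM.
Compound 3 `CN(C)CCn1cnnc1-c1cc(Oc2ccc(NC(=O)N/N=C/c3ccc(F)cc3F)cc2F)ccn1` gives 5030 nM.

Compound 1 has the lowest of the three numbers, with compound 3 nearest and compound 2 furthest, but both gaps fall within the usual scatter, so no order among the three compounds can be stated from these values.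

Compound 4 `CN(C)CCn1cnnc1-c1cc(Oc2ccc(NC(=O)N/N=C/c3ccc(Cl)cc3)cc2F)ccn1` has not yet been measured. It differs from compound 1 in one place: 4-chlorophenyl in place of 1H-indol-3-yl on a carbon with a double bond to nitrogen

Among the compounds with values here, two measured steps bear on this change, since each one swaps the same 1H-indol-3-yl for a substituted phenyl on the carbon with a double bond to nitrogen: a 1.9-fold higher number from compound 1 to compound 2 (0.28 log units; within the scatter) and a 1.4-fold higher number from compound 1 to compound 3 (0.14 log units; within the scatter). Both numbers moved slightly higher and both stayed within the scatter. The step between the two phenyl variants, a 1.4-fold lower number from compound 2 to compound 3 (0.13 log units; within the scatter), is also within the scatter. Nothing measured here separates one phenyl variant from another. For compound 4 the expected step in this assay is therefore small and, if anything, toward a higher number, estimated as a 1.3-fold higher number from compound 1 to compound 4 (0.12 log units; within the scatter).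

Compound 4 is estimated at 4800 nM, with a range from 2200 nM to 10500 nM.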

Compound 4, half-maximal inhibitory concentration: 1870 nM
Estimate against measurement, compound 4: 2.6-fold (0.41 log units) above, and the stated range ends above it.
By their numbers in this assay, from the lowest: compounds 4, 1, 3 and 2 (each within the scatter of the next, the first and the last beyond it).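

In this assay, within the data shown here, the carbon with a double bond to nitrogen now gives steps beyond the scatter, which no earlier pair did: 4-chlorophenyl in place of 2,4-difluorophenyl gives a modest step (a 2.7-fold lower number from compound 3 to compound 4 (0.43 log units; beyond the scatter)), and 4-chlorophenyl in place of 2-(nitrooxy)phenyl gives another (a 3.7-fold lower number from compound 2 to compound 4 (0.56 log units; beyond the scatter)). The substituted phenyl groups at this place are therefore not interchangeable, although compound 2 and compound 3 remain within the scatter of each other. The change from 1H-indol-3-yl, with its hydrogen-bond donor, to 4-chlorophenyl, with none, stays within the scatter (a 1.9-fold lower number from compound 1 to compound 4 (0.29 log units; within the scatter)), so these two groups cannot be ordered, and nothing available accounts for the separation among the phenyl variants.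

Still open, on these data alone, is whether the chlorine of 4-chlorophenyl carries the separation, a question that plain phenyl or 4-bromophenyl on this carbon would address. A phenyl bearing an amine or a carboxylic acid would show how far the number at this place can move beyond the range seen with these four compounds.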